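Aryl ketone variation on the shared core

The source may hold more compounds than are shown below. What is called first, only, known or untested is meant among the compounds shown, and "the series" means these compounds.

Measured so far:
compound 1 `COc1cc(-c2cc(/C=C/C(=O)c3ccc(N)cc3)[nH]n2)cc(OC)c1OC` gives -64% in a functional assay on M14 cells (Homo sapiens) for cytotoxicity, read by sulforhodamine B assay, with a stated time of 48 h, tested at 10 uM; a lower number here means a stronger effect, a higher number a weaker effect of the compound at the concentration tested
compound 2 `COc1cc(-c2cc(/C=C/C(=O)c3ccc(Cl)c(Cl)c3)[nH]n2)cc(OC)c1OC` gives 61% in this assay

Going by the values given here, compound 2 stands highest of the two numbers in this assay; the only measured step, a number 125 percentage points higher from compound 1 to compound 2 (beyond the scatter), is large and beyond the scatter. Compound 3 `COc1ccc(C(=O)/C=C/c2cc(-c3cc(OC)c(OC)c(OC)c3)n[nH]2)cc1OC` differs from compound 2 by 3,4-dimethoxyphenyl in place of 3,4-dichlorophenyl on a carbonyl carbon. The measured step bears on this only loosely: it shows that the group on the carbonyl carbon can move the read-out a long way, but it exchanged 4-aminophenyl for 3,4-dichlorophenyl, whereas here 3,4-dichlorophenyl gives way to 3,4-dimethoxyphenyl. Among the compounds with values here, no measured step carries two hydrogen-bond acceptors into that place, so direction is uncertain. A moderate move back toward compound 1 is expected, a number 41 percentage points lower from compound 2 to compound 3 (beyond the scatter), with wide uncertainty. For compound 3 the estimate in this assay is 20%, within -40% to 70%.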

Compound 3, a percentage reported as activity, at one concentration (the size of the read-out at that concentration, not a potency): -72%
Estimate against measurement, compound 3: 92 percentage points above; the measured number lies below the stated range.
By their numbers in this assay, from the lowest: compounds 3 and 1 (each within the scatter of the next); then compound 2.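

In this assay, the large swing at the carbonyl carbon is not tied to 4-aminophenyl: replacing 3,4-dichlorophenyl with 3,4-dimethoxyphenyl also gives a large step (a number 133 percentage points lower from compound 2 to compound 3 (beyond the scatter)). The comparison with 4-aminophenyl shows no difference beyond the scatter (a number 8 percentage points lower from compound 1 to compound 3 (within the scatter)), so two different aryl groups at this place give matching read-outs, and among these three compounds only the 3,4-dichlorophenyl compound stands apart. Nothing at hand accounts for this split.

Going by these compounds alone, it remains open whether the split follows the chlorine atoms, the methoxy groups or the amine, since each group is seen in only one compound. Unsubstituted phenyl, 4-chlorophenyl and 4-methoxyphenyl at the same place would help separate these readings.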